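Nitro to Amino Swap Tested on a Second Core

This account rests on a few compounds, and the source may have more. Where it says the series, first, only, none or still open, it means among the compounds named here.

Measured compounds:
Compound 1 `COc1ccc(-n2ccnc2-c2cc(OC)c(OC)c(OC)c2)cc1[N+](=O)[O-]` gives 2500 nM in a functional assay on HeLa cells (Homo sapiens) for antiproliferative activity, read by MTT assay, with a stated time of 72 h; on this read-out higher numbers stand for weaker inhibition and lower numbers for stronger inhibition.
Compound 2 `COc1ccc(-n2ccnc2-c2cc(OC)c(OC)c(OC)c2)cc1N` gives 80 nM in this assay.
Compound 3 `COc1ccc(NC(=O)c2cc(OC)c(OC)c(OC)c2)cc1[N+](=O)[O-]` gives 38700 nM in this assay.

Compound 1 and compound 2 share one core and differ in a single place: amino in place of nitro on an aromatic carbon. That change made a large step, a 31-fold lower number from compound 1 to compound 2 (1.49 log units; beyond the scatter), so among these two the amino compound is the stronger inhibitor.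

Compound 3 has a different core, in which the two aromatic rings are joined through an amide rather than through the ring system of compound 1. How the two cores differ is not broken down here. Compound 3 gives the highest number of the three measured compounds in this assay.

Compound 4 `COc1ccc(NC(=O)c2cc(OC)c(OC)c(OC)c2)cc1N` has not yet been measured. It stands to compound 3 exactly as compound 2 stands to compound 1: amino in place of nitro on an aromatic carbon. The place of the change is described in the same words for both pairs, so this is the same change carried onto the second core.

The expectation for compound 4 rests on the step of a 31-fold lower number from compound 1 to compound 2 (1.49 log units; beyond the scatter) seen on the first core. Because compound 3 gives 38700 nM, a step of the same size would leave compound 4 well into the measurable range. Since the core differs and a single earlier example carries that size, the expected step is taken somewhat smaller, a 13-fold lower number from compound 3 to compound 4 (1.11 log units; beyond the scatter), with wide uncertainty. Compound 4 is therefore estimated at 3000 nM, expected between 600 nM and 15000 nM.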

Compound 4, half-maximal inhibitory concentration: 4100 nM
Estimate against measurement, compound 4: 1.4-fold (0.14 log units) below, and the stated range covers the measured number.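

On the second core, amino in place of nitro again gives the stronger inhibitor in this assay, with a 9.4-fold lower number from compound 3 to compound 4 (0.97 log units; beyond the scatter), so the direction of the step carried over from the core of compound 1 to the core of compound 3. The size of the step did not carry over unchanged, and the two cores gave clearly different steps for the same change: the same change on two cores in this assay, a 31-fold lower number (1.49 log units; beyond the scatter) from compound 1 to compound 2 and a 9.4-fold lower number (0.97 log units; beyond the scatter) from compound 3 to compound 4, 3.3-fold (0.52 log units) apart, beyond the scatter of two such steps These two pairs show that the swap can be carried to a new core with the same direction of effect, but they do not show what sets the size of the step, or whether a third core would follow the same direction.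

From the compounds shown here alone, what a hydroxyl group, a methylamino group or an acetamide would do at the same place on the ring remains open, so it cannot yet be said how much of the step depends on the amino group itself. All four numbers come from this assay, which leaves open whether the same steps would appear in other cell types or on other read-outs.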